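The source may hold more compounds than are shown below. What is called first, only, known or untested is meant among the compounds shown, and "the series" means these compounds.

Measured in an ADME assay on cells (Homo sapiens) for cytotoxicity, read by resazurin assay, with a stated time of 5 days; a higher number here means that more compound is tolerated, a lower number that less compound is tolerated:
Compound 1 `CCC1=C(C(=O)OCC2CCCCC2)C(c2cccc(O)c2)NC(=O)N1`: > 10000 nM, a limit
Compound 2 `COc1ccc(-c2nc(COc3cccc(Cl)c3)nc3ccsc23)cn1`: > 50000 nM, a limit
Compound 3 `COc1ccc(-c2nc(CNc3cccc(Cl)c3)nc3ccsc23)cn1`: > 50000 nM, a limit

None of these three results is a true number, so the compounds cannot be ranked against one another. Compound 3 gives only a limit, > 50000 nM. It stands at the limit of > 50000 nM in this assay, at which 2 of the 3 values shown sit. The remaining result is the limit of > 10000 nM in this assay, at which 1 of the 3 values shown sits.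

The next compound is compound 4 `COc1ccc(-c2nc(CSc3cc(C)cc(C)c3)nc3ccsc23)cn1`, which keeps the shared core and changes one group. The change is (3,5-dimethylphenyl)sulfanyl in place of (3-chlorophenyl)amino on a saturated chain carbon bound to an aromatic carbon. In words, (3,5-dimethylphenyl)sulfanyl replaces (3-chlorophenyl)amino on a saturated chain carbon bound to an aromatic carbon.

For the measured compounds named here, only one measured step involves this same place, and it is a step that the two limits leave unreadable from compound 2 to compound 3. That step shows no measurable change, but it gives no size to carry forward either. Going by the values given here, no measured step involves the (3,5-dimethylphenyl)sulfanyl group. With so little to go on, no step beyond the usual scatter is expected in this assay, in either direction, and another limit is the most likely result.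

For compound 4, the estimated value is 50000 nM, with an expected range from 20000 nM to 100000 nM. This estimate means an expected a number no higher from compound 3 to compound 4 (the limit leaves the size open).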

Compound 4, half-maximal cytotoxic concentration: > 50000 nM
Compound 4: no number, only a limit; the forecaster's own chance of this, stated with the estimate: 70%; the middle value sits exactly at the limit.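

No new step can be read from compound 4: its result in this assay is only a limit, like those of compound 2 and compound 3, and the steps joining compound 4 to these two cannot be read. The compounds shown leave open what concentration of any of them is actually cytotoxic, and whether changing the group on the saturated chain carbon alters it.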